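Swapping the aryl on the sulfonamide nitrogen

The source may hold more compounds than are shown below. What is called first, only, known or untested is meant among the compounds shown, and "the series" means these compounds.

Compound 2 (`O=C1NCCN1c1ccc(S(=O)(=O)Nc2cccc(Br)c2)cc1`) gives 77 nM in a functional assay on HT-29 cells (Homo sapiens) for antiproliferative activity, read by sulforhodamine B assay, with a stated time of 48 h (on this read-out lower numbers stand for stronger inhibition and higher numbers for weaker inhibition), and stands lowest of the two numbers shown. Compound 1 (`CCCCCc1ccc(NS(=O)(=O)c2ccc(N3CCNC3=O)cc2)cc1`) gives 990 nM in this assay. Compound 3 (`CC(C)Cc1ccc(NS(=O)(=O)c2ccc(N3CCNC3=O)cc2)cc1`) reaches only a limit of this assay, > 1000 nM in this assay. Within the data shown here, the single measured step, a number no lower from compound 1 to compound 3 (the limit leaves the size open), sits on a chain elsewhere in the shared core and ends at the limit of > 1000 nM in this assay, at which 1 of the 3 values shown sits, so its size cannot be read. The change followed here is 2-methoxyphenyl in place of 3-bromophenyl on a sulfonamide nitrogen, which yields compound 4 (`COc1ccccc1NS(=O)(=O)c1ccc(N2CCNC2=O)cc1`). Among the measured compounds shown here, no measured step touches this position; the values of compound 2 and compound 1 show only that the ring on the sulfonamide nitrogen can move the number beyond the scatter. Compound 4 is expected near 400 nM (from 100 nM to 2000 nM). The estimated step is a 5.2-fold higher number from compound 2 to compound 4 (0.72 log units; beyond the scatter), a weakening.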

Compound 4, half-maximal inhibitory concentration: 550 nM
Compound 4: the middle estimate sits 1.4-fold (0.14 log units) below what was measured; measured number inside the range.
By their numbers in this assay, from the lowest: compound 2; then compounds 4 and 1 (each within the scatter of the next). At a limit, above all of these: compound 3.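

Among these compounds, this is the first measured step at this position. In this assay, 2-methoxyphenyl in place of 3-bromophenyl on a sulfonamide nitrogen gives a 7.1-fold higher number from compound 2 to compound 4 (0.85 log units; beyond the scatter), so this one exchange of ring weakens the result by more than the usual scatter. Nothing shown gives a reason for this weakening.

This single pair cannot separate the effect of losing the bromine from that of gaining the methoxy group. Also open, going by these compounds, is how a plain phenyl ring, or a phenyl ring carrying an amine or a carboxylic acid, would read here.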